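A few compounds are considered here, and "the series" means these few. Any claim that something is new, unique, unknown or untested is made for them only; others in the source may bear on it.

Working notes on the series.

Of the compounds shown here, three have a number so far: compound 1 `CCCCc1cc(C(C)=O)c(O)cc1OCCCCC#N`, compound 2 `C=CCc1cc(C(C)=O)c(O)cc1OCCCCCC#N` and compound 3 `CCc1cc(C(C)=O)c(O)cc1OCCCCCC(C)(C)c1nnn(C)n1`. In an assay on isolated protein for inhibition of leukotriene B4 receptor 1 (Homo sapiens), tested at 10 uM (on this read-out lower numbers stand for less inhibition and higher numbers for more inhibition at the one concentration tested (going by the name of the read-out)), compound 1 gives 41%. In this assay compound 2 gives 81%, the second highest of the three numbers. In this assay compound 3 gives 95%, which lies above compound 2 by more than the scatter, and compound 1 lies below compound 2 by more than the scatter. No two of these compounds differ in one place only, so none of the gaps can be tied to a single change.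

Compound 4 `C=CCc1cc(C(C)=O)c(O)cc1OCCCCCCC` has not been measured. It differs from compound 2 in one place: ethyl in place of cyano on a saturated chain carbon, five bonds along the chain from an oxygen on an aromatic ring. Going by the values given here, with no measured single-place step to rest on, the direction is open; a moderate fall from compound 2 is expected rather than none, with the estimated step of a number 16 percentage points lower from compound 2 to compound 4 (beyond the scatter). In this assay compound 4 is estimated at 65%, in a range from 35% to 90%.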

Compound 4, a percentage reported as inhibition, at one concentration (the size of the read-out at that concentration, not a potency): 31%
The estimate for compound 4 lay 34 percentage points above the measured number, outside the stated range (below it).
By their numbers in this assay, from the lowest: compounds 4 and 1 (each within the scatter of the next); then compound 2; then compound 3.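

Going by these compounds alone, this is the first single-place step: in this assay the change of ethyl in place of cyano on a saturated chain carbon, five bonds along the chain from an oxygen on an aromatic ring, gives a number 50 percentage points lower from compound 2 to compound 4 (beyond the scatter) and is large. The number of heavy atoms stays the same in this change, so a large step here comes with the loss of the nitrogen, the triple bond and the hydrogen-bond acceptor, and the nitrile end of the chain is not interchangeable with an all-carbon end on this core. Nothing measured here explains the size of this step, or separates those three losses from one another.

From the compounds shown here alone, whether a carboxylic acid or a primary amide at the end of the chain would keep the higher number remains open. Also open, going by these compounds, is whether the same change gives a step of this size with a shorter or longer chain, or with the butyl or ethyl group of the other compounds on the core.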